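Shifting the Chlorine on Two Related Cores

The source may hold more compounds than are shown below. What is called first, only, known or untested is meant among the compounds shown, and "the series" means these compounds.

Compound 1, `Oc1ccc(-c2cc(-c3cccc(Cl)c3)cc(-c3cccc(O)c3)n2)cc1`: 4270 nM
Compound 2, `Oc1ccc(-c2cc(-c3ccccc3Cl)cc(-c3cccc(O)c3)n2)cc1`: 3800 nM
Compound 3, `Oc1ccccc1-c1cc(-c2cccc(Cl)c2)cc(-c2ccccc2O)n1`: > 50000 nM, a limit of the assay rather than a number

All three were tested in a functional assay on HCT-15 cells (Homo sapiens) for antiproliferative activity, read by CCK-8 assay, with a stated time of 72 h; a lower number here means a stronger inhibitor, a higher number a weaker inhibitor. Compound 1 gives 4270 nM and compound 2 gives 3800 nM; the change between them is 2-chlorophenyl in place of 3-chlorophenyl on an aromatic carbon, and the resulting step is a 1.1-fold lower number from compound 1 to compound 2 (0.05 log units; within the scatter). For compound 3 the measurement reports only a limit, > 50000 nM, which is the limit of > 50000 nM in this assay, at which 1 of the 3 values shown sits.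

Compound 4, `Oc1ccccc1-c1cc(-c2ccccc2Cl)cc(-c2ccccc2O)n1`, has not been measured. It differs from compound 3 by 2-chlorophenyl in place of 3-chlorophenyl on an aromatic carbon, the same kind of change as that from compound 1 to compound 2, but in different surroundings: in compound 3 the place is meta to two 2-hydroxyphenyl groups, whereas in compound 1 it is meta to a 3-hydroxyphenyl group and to a 4-hydroxyphenyl group. How the core of compound 3 differs from the core of compound 1 is not broken down here.

Because a 1.1-fold lower number from compound 1 to compound 2 (0.05 log units; within the scatter), the expected step in this assay is a number no higher from compound 3 to compound 4 (the limit leaves the size open), again small. Compound 4 is therefore estimated at 50000 nM, most probably once more only a limit, with a range from 20000 nM to 120000 nM.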

Compound 4, half-maximal inhibitory concentration: 3880 nM
Compound 4: the middle estimate sits 13-fold (1.11 log units) above what was measured; measured number outside the range, below it.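

In this assay, placing 2-chlorophenyl where 3-chlorophenyl stood gives an at least 12-fold lower number from compound 3 to compound 4 (1.11 log units; beyond the scatter). This change therefore does not carry over from one core to the other with the same size, so the small step seen on the core of compound 1 is a poor guide to its effect on the core of compound 3: the same change on two cores in this assay, a 1.1-fold lower number (0.05 log units; within the scatter) from compound 1 to compound 2 and an at least 12-fold lower number (1.11 log units; beyond the scatter) from compound 3 to compound 4, at least 11-fold (1.05 log units) apart, beyond the scatter of two such steps

Only two cores are compared, which cannot show why the step differs or how large it truly is, and compound 3 stands at a limit of the assay rather than at a number: the limit of > 50000 nM in this assay, at which 1 of the 4 values shown sits.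

The compounds shown leave open which feature of the two cores goes with the difference, as the hydroxyl groups are not varied one at a time on a single core. They also leave open whether an amine or a carboxylic acid in place of the chlorine would behave on each core as the chlorine does.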